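Two More Carbons on the Chain

The compounds below may be only part of what the source reports. "The series", "measured", "known", "first", "only" and "open" are said of these compounds alone.

In a functional assay on cells (T-cell line, Homo sapiens) for inhibition (on this read-out lower numbers stand for stronger inhibition and higher numbers for weaker inhibition), compound 1 `CCN1CCC(COC(c2ccccc2)c2ccccc2)CC1` gives > 20000 nM, which is a limit and not a number. Within the data shown here, compound 2 `CCCCCCN1CCC(COC(c2ccccc2)c2ccccc2)CC1` gives 5500 nM, the only true number so far. Among the measured compounds shown here, the single measured step, an at least 3.6-fold lower number from compound 1 to compound 2 (0.56 log units; beyond the scatter), came with butyl in place of hydrogen. Compound 3 `CCCCCCCCN1CCC(COC(c2ccccc2)c2ccccc2)CC1` carries a related, smaller change: ethyl in place of hydrogen on a saturated chain carbon, six bonds along the chain from an amine nitrogen in a ring. On that one step alone, a further modest move toward a lower number is expected in this assay. The expected step is a 2.2-fold lower number from compound 2 to compound 3 (0.34 log units; beyond the scatter). For compound 3 the estimated value is 2500 nM, with an expected range from 700 nM to 7000 nM.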

Compound 3, half-maximal inhibitory concentration: 700 nM
Compound 3: the middle estimate sits 3.6-fold (0.55 log units) above what was measured; the measured number falls inside the stated range.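

In this assay, the chain on the ring nitrogen keeps paying as it grows: ethyl in place of hydrogen, six bonds along the chain from an amine nitrogen in a ring, gives a 7.9-fold lower number from compound 2 to compound 3 (0.90 log units; beyond the scatter). Among these compounds, this is the first step here measured between two true numbers, so its size can be read directly. Across the whole chain, hexyl in place of hydrogen gives an at least 28-fold lower number from compound 1 to compound 3 (1.45 log units; beyond the scatter), although the value of compound 1 is a limit and not a number.

Going by these compounds, whether a longer chain would lower the number further or raise it again stays open. So does the effect of an amine or a carboxylic acid carried on the chain.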